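Aryl ether variation on the shared core: permeability notes

This account rests on a few compounds, and the source may have more. Where it says the series, first, only, none or still open, it means among the compounds named here.

Compound 1 `Cc1ccnc([C@@H](C)Oc2cc3oc(=O)n(CCC(=O)O)c3cc2Cl)c1` gives in a physicochemical assay for permeability, using PAMPA (on this read-out higher numbers stand for higher permeability and lower numbers for lower permeability), only an assay limit, < 3 nm/s.
Compound 2 `O=C(O)CCn1c(=O)oc2cc(Cl)c(Cl)cc21` gives in this assay 24 nm/s.
Compound 3 `O=C(O)CCn1c(=O)oc2cc(OCC3CCC3)c(Cl)cc21` gives in this assay 12 nm/s.

Compound 3 holds the lower of the two numbers reported; its nearest neighbour is compound 2, and the two sit within the scatter of each other, so no order between them is claimed. For the measured compounds named here, the single measured step, a 2.0-fold lower number from compound 2 to compound 3 (0.30 log units; within the scatter), is likewise within the scatter.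

Compound 4 `C[C@@H](Oc1cc2oc(=O)n(CCC(=O)O)c2cc1Cl)c1ncco1` differs from compound 3 by a group of 7 heavy atoms (5 carbon, 1 nitrogen, 1 oxygen; one five-membered aromatic ring with 2 hetero atoms) in place of a group of 5 heavy atoms (5 carbon; one four-membered non-aromatic ring of carbon only), on an oxygen on an aromatic ring.

Bearing on this step: only a 2.0-fold lower number from compound 2 to compound 3 (0.30 log units; within the scatter), which changes the group on the same aromatic carbon and was within the scatter. Compound 1, which also carries an ether on that aromatic carbon, reaches only the assay limit, (the limit of < 3 nm/s in this assay, at which 1 of the 3 values shown sits). Compound 4 is therefore expected to fall below the numbers of compounds 2 and 3, with a step of a 3.0-fold lower number from compound 3 to compound 4 (0.48 log units; beyond the scatter) estimated to go beyond the scatter, and a fair chance that the measurement again returns only a limit.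

Estimated value for compound 4 in this assay: 4 nm/s, range 1.5 nm/s to 12 nm/s.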

Compound 4, apparent permeability: < 3 nm/s
Compound 4 gave a limit, no number; the forecaster's own chance of this, stated with the estimate: 45%; middle value at least 1.3-fold (0.12 log units) away from the limit.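

Unlike the step from compound 2 to compound 3, which stayed within the scatter, a change in the group on this ether oxygen does move the read-out in this assay. Exchanging cyclobutylmethyl for the group carrying a five-membered aromatic ring with 2 hetero atoms gives an at least 4.0-fold lower number from compound 3 to compound 4 (0.60 log units; beyond the scatter), and the full exchange of the chlorine atom on the aromatic carbon gives an at least 8.0-fold lower number from compound 2 to compound 4 (0.90 log units; beyond the scatter). An ether at this place is therefore not enough to settle the outcome: compound 3 keeps a measured number, whereas compound 1 and compound 4, both with an aromatic ring on the saturated chain carbon bound to the ether oxygen, return only a limit: the limit of < 3 nm/s in this assay, at which 2 of the 4 values shown sit.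

With two limits, the step from compound 1 to compound 4 cannot be read, so 4-methylpyridin-2-yl and 1,3-oxazol-2-yl remain unordered in this assay. Also open, as far as these compounds go, is whether the lower reading goes with the aromatic ring or with the methyl branch on the chain carbon, and how an unbranched chain ending in phenyl or an amine on the same oxygen would read.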